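Swapping the anilino for a phenyl-bearing saturated ring

The compounds below may be only part of what the source reports. "The series", "measured", "known", "first", "only" and "open" are said of these compounds alone.

Compound 1 `CC(C(=O)NCc1ccc(C(F)(F)F)nc1Nc1ccccc1)c1ccc(NS(C)(=O)=O)c(F)c1` is examined in a functional assay on CHO-K1 cells for antagonist activity at transient receptor potential cation channel subfamily V member 1 (Homo sapiens), read by FLIPR (a lower number here means a stronger inhibitor, a higher number a weaker inhibitor), where compound 1 gives 1400 nM. Among the compounds with a number, compound 1 stands highest of two. Its nearest neighbour is compound 3 `CC(C(=O)NCc1ccc(C(F)(F)F)nc1N1CC=CCC1)c1ccc(NS(C)(=O)=O)c(F)c1`, which in this assay gives 12.1 nM; the step is a 120-fold lower number from compound 1 to compound 3 (2.06 log units; beyond the scatter). Compound 2 `CC(C(=O)NCc1ccc(C(F)(F)F)nc1NCc1cccnc1)c1ccc(NS(C)(=O)=O)c(F)c1` is reported in this assay as "not active" (no number reported), with no number given.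

The compound not yet measured is compound 4 `CC(C(=O)NCc1ccc(C(F)(F)F)nc1N1CCC(c2ccccc2)CC1)c1ccc(NS(C)(=O)=O)c(F)c1`. Relative to compound 1 the change is 4-phenylpiperidin-1-yl in place of anilino on an aromatic carbon.

Among the compounds with values here, the step that bears on this change is the one from compound 1 to compound 3, in which the anilino was likewise replaced by a six-membered non-aromatic ring with one hetero atom attached on the same aromatic carbon, and it was large, a 120-fold lower number from compound 1 to compound 3 (2.06 log units; beyond the scatter). Compound 4 carries the same kind of non-aromatic ring, now bearing an additional six-membered aromatic ring of carbon only, so a step in the same direction, though of less certain size, is expected in this assay.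

For compound 4 the estimate is therefore 40 nM, within 6 nM to 300 nM, which is expected to be a step of a 35-fold lower number from compound 1 to compound 4 (1.54 log units; beyond the scatter).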

Compound 4, half-maximal inhibitory concentration: 25 nM
Estimate against measurement, compound 4: 1.6-fold (0.20 log units) above; measured number inside the range.
By their numbers in this assay, from the lowest: compound 3; then compound 4; then compound 1.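

Compound 4 shows that the gain over anilino at this position is not limited to the unsubstituted ring of compound 3: in this assay the 4-phenylpiperidin-1-yl group, with its 12 heavy atoms, still brings a large drop (a 56-fold lower number from compound 1 to compound 4 (1.75 log units; beyond the scatter)). The aromatic ring of carbon only, which in anilino goes with a weak number, is therefore compatible with a low number once it is carried on the non-aromatic ring. Against compound 3, the larger group costs only a modest amount (a 2.1-fold higher number from compound 3 to compound 4 (0.32 log units; beyond the scatter)), so this position on the aromatic carbon next to the ring nitrogen accepts considerably more bulk in heavy-atom count without returning to the level of compound 1. No measurement given here accounts for either step.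

The compounds shown leave open whether the ring itself is needed, as an open-chain amine such as diethylamino or a morpholin-4-yl ring might behave differently. They also leave open how much of the step between compound 3 and compound 4 belongs to the phenyl alone, and whether a benzyl or a 4-hydroxy group on the piperidine would serve as well.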